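A Fluorophenyl Ester in a Glycoside Antiproliferative Series

A few compounds are considered here, and "the series" means these few. Any claim that something is new, unique, unknown or untested is made for them only; others in the source may bear on it.

Measured compounds:
compound 1, `C/C=C1/[C@H](O[C@@H]2O[C@H](CO)[C@@H](O)[C@H](O)[C@H]2O)OC=C(C(=O)OC)[C@H]1CC(=O)OCCc1ccc(O)c(O)c1` — 160000 nM
compound 2, `C/C=C1/[C@H](O[C@@H]2O[C@H](CO)[C@@H](O)[C@H](O)[C@H]2O)OC=C(C(=O)OC)[C@H]1CC(=O)OCCc1ccc(OC)c(OC)c1` — > 15000 nM
compound 3, `C/C=C1/[C@H](O[C@@H]2O[C@H](CO)[C@@H](O)[C@H](O)[C@H]2O)OC=C(C(=O)OC)[C@H]1CC(=O)OCC` — > 15000 nM

Compound 1 carries the 3,4-dihydroxyphenyl group on a saturated chain carbon, two bonds along the chain from an oxygen next to a carbonyl group. For the measured compounds named here, in a functional assay on SK-BR-3 cells (Homo sapiens) for antiproliferative activity, read by MTT assay, with a stated time of 72 h (on this read-out higher numbers stand for weaker inhibition and lower numbers for stronger inhibition), compound 1 gives 160000 nM, and this is the only actual number in the set. For compound 2 the read-out is a limit of this assay, > 15000 nM. For compound 3 the read-out is also a limit, > 15000 nM. The step that the limit leaves unreadable from compound 1 to compound 2 and the step that the limit leaves unreadable from compound 1 to compound 3 are therefore both unreadable in size, a consequence of the limit of > 15000 nM in this assay, at which 2 of the 3 values shown sit.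

Compound 4, `C/C=C1/[C@H](O[C@@H]2O[C@H](CO)[C@@H](O)[C@H](O)[C@H]2O)OC=C(C(=O)OC)[C@H]1CC(=O)OCCc1ccc(F)cc1`, differs from compound 1 in one place: 4-fluorophenyl in place of 3,4-dihydroxyphenyl on a saturated chain carbon, two bonds along the chain from an oxygen next to a carbonyl group. Both measured steps that remove or cap the 3,4-dihydroxyphenyl group bear on this change, but neither gives a readable size or direction, so no step beyond the scatter can be claimed in either direction. Compound 4 is expected to sit near the limit region, with an estimate of 100000 nM and a range from 20000 nM to 500000 nM. The step this estimate means, a 1.6-fold lower number from compound 1 to compound 4 (0.20 log units; within the scatter), is expected to be small relative to the scatter.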

Compound 4, half-maximal inhibitory concentration: > 20000 nM
Compound 4 gave a limit, no number (the forecaster's own chance of this, stated with the estimate: 70%); the middle value is on the limit's open side.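

In this assay compound 4 gives > 20000 nM, which is a limit of the assay and not a number. Its steps from compound 1, compound 2 and compound 3 cannot be read in size or direction. The compounds shown leave open whether 4-fluorophenyl, 3,4-dimethoxyphenyl, 3,4-dihydroxyphenyl or hydrogen at this saturated chain carbon changes the read-out at all.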